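Trading a methyl branch for a hydroxyl-bearing branch on an amino alcohol

The compounds below may be only part of what the source reports. "The series", "measured", "known", "first", "only" and "open" are said of these compounds alone.

Measured compounds:
compound 1, `CCCCCCCCC[C@@H](O)[C@H](C)N`, 6600 nM
compound 2, `CCCCCCCCC[C@@H](O)[C@@H](N)C(C)C`, 14000 nM

In a functional assay on HBL-100 cells (Homo sapiens) for antiproliferative activity, read by sulforhodamine B assay, with a stated time of 48 h (a lower number here means a stronger inhibitor of growth, a higher number a weaker inhibitor of growth), compound 2 gives 14000 nM, the highest of the two numbers, and compound 1 gives 6600 nM. Among the measured compounds shown here, the one measured step, a 2.1-fold higher number from compound 1 to compound 2 (0.33 log units; beyond the scatter), shows that enlarging the group on the carbon that carries the amine weakens growth inhibition modestly.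

Compound 3, `CCCCCCCCC[C@@H](O)[C@@H](N)[C@@H](C)O`, has not yet been measured. It differs from compound 2 as follows: 1-hydroxyethyl in place of isopropyl on a saturated chain carbon bound to an amine nitrogen and a saturated chain carbon. For the measured compounds named here, no measured step shows what adding a hydroxyl at this place does, so the single step from compound 1 to compound 2 is the only guide, and it concerns size rather than a hydroxyl. The new group keeps the branching of isopropyl, so a step in this assay no larger than the scatter is expected, a 1.4-fold lower number from compound 2 to compound 3 (0.15 log units; within the scatter). Compound 3 is therefore estimated at 10000 nM, within 3500 nM to 30000 nM.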

Compound 3, concentration for 50% growth inhibition: 13000 nM
Beside the measured number, compound 3's estimate is 1.3-fold (0.11 log units) below it; measured number inside the range.
By their numbers in this assay, from the lowest: compounds 1, 3 and 2 (each within the scatter of the next, the first and the last beyond it).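

In this assay, putting 1-hydroxyethyl in place of isopropyl on this saturated chain carbon gives a 1.1-fold lower number from compound 2 to compound 3 (0.03 log units; within the scatter) so a branch with one hydrogen-bond donor and one acceptor, where isopropyl has neither, reads the same as isopropyl here. Set against methyl, 1-hydroxyethyl gives a 2.0-fold higher number from compound 1 to compound 3 (0.29 log units; within the scatter) and that step stays inside the scatter, while the step to isopropyl, a 2.1-fold higher number from compound 1 to compound 2 (0.33 log units; beyond the scatter) lies beyond it, so only isopropyl is clearly separated from methyl. No measurement is available that could explain these results.

The compounds shown leave open whether the opposite arrangement at the new stereocentre of 1-hydroxyethyl would read the same. They also leave open what a carboxylic acid or a second amine on this branch would do to the number.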